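Chlorophenyl Position on the Aroyl Carbonyl: Compound 4

The compounds below may be only part of what the source reports. "The series", "measured", "known", "first", "only" and "open" are said of these compounds alone.

Measured so far in a functional assay on NUGC-3 cells (Homo sapiens) for cytotoxicity, read by sulforhodamine B assay, with a stated time of 72 h; on this read-out higher numbers stand for weaker inhibition of growth and lower numbers for stronger inhibition of growth:
- compound 1, `O=C(Nc1cc(C(F)(F)F)cc(C(F)(F)F)c1)C1CCc2ccccc2N1C(=O)c1ccc(Cl)cc1`: 1660 nM
- compound 2, `CC(=O)N1c2ccccc2CCC1C(=O)Nc1cc(C(F)(F)F)cc(C(F)(F)F)c1`: > 70000 nM (a limit of the assay)
- compound 3, `O=C(Nc1cc(C(F)(F)F)cc(C(F)(F)F)c1)C1CCc2ccccc2N1C(=O)c1cccc(Cl)c1`: 560 nM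

Compound 3 stands lowest of the two numbers; its nearest neighbour is compound 1, separated by a 3.0-fold lower number from compound 1 to compound 3 (0.47 log units; beyond the scatter). Compound 2 gives only a limit, (the limit of > 70000 nM in this assay, at which 1 of the 3 values shown sits). Replacing the aroyl group by an acetyl group is the large step of an at least 42-fold higher number from compound 1 to compound 2 (1.62 log units; beyond the scatter), and going back from acetyl to the 3-chlorophenyl ketone is an at least 120-fold lower number from compound 2 to compound 3 (2.09 log units; beyond the scatter).

Compound 4, `O=C(Nc1cc(C(F)(F)F)cc(C(F)(F)F)c1)C1CCc2ccccc2N1C(=O)c1ccccc1Cl`, keeps the whole aroyl amide of compound 3 and moves only the chlorine: 2-chlorophenyl in place of 3-chlorophenyl on a carbonyl carbon. Among the compounds with values here, the one measured step that bears on this is the shift of chlorine between the 4- and 3-positions, a 3.0-fold lower number from compound 1 to compound 3 (0.47 log units; beyond the scatter), which was modest and beyond the scatter but far smaller than the aryl-to-methyl steps. A chlorine shift of similar size is therefore expected here, in either direction, with the whole aroyl amide retained keeping compound 4 well away from the limit of compound 2. Compound 4 is estimated at 900 nM, from 250 nM to 3000 nM, which means an expected step of a 1.6-fold higher number from compound 3 to compound 4 (0.21 log units; within the scatter).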

Compound 4, concentration for 50% growth inhibition: 1930 nM
Compound 4: middle estimate off by 2.1-fold (0.33 log units), on the low side; the measured number falls inside the stated range.
By their numbers in this assay, from the lowest: compound 3; then compounds 1 and 4 (each within the scatter of the next). At a limit, above all of these: compound 2.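

In this assay, moving the chlorine away from the 3-chlorophenyl group now gives a number beyond the scatter in a second direction, a 3.4-fold higher number from compound 3 to compound 4 (0.54 log units; beyond the scatter), so compound 3 stands apart from both other chlorophenyl amides. The 2-chlorophenyl and 4-chlorophenyl groups cannot be told apart here, a 1.2-fold higher number from compound 1 to compound 4 (0.07 log units; within the scatter), so among compounds 1, 3 and 4 chlorine position does not follow a steady trend and only the 3-chlorophenyl group stands out. With the chlorine in the third position tested, the aroyl amide still stays far from the acetyl amide, an at least 36-fold lower number from compound 2 to compound 4 (1.55 log units; beyond the scatter), although compound 2 gives only a limit, so this step is a bound: the limit of > 70000 nM in this assay, at which 1 of the 4 values shown sits.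

Open, from the compounds shown here alone, is whether the advantage of the 3-chlorophenyl group depends on chlorine itself or would persist with a fluorine, a methoxy group, a nitrile, an amine or a carboxylic acid in its place. Also open, going by these compounds, are whether a dichlorophenyl group would add to or cancel the single-chlorine result, and whether the same order holds on other cell lines.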